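This account rests on a few compounds, and the source may have more. Where it says the series, first, only, none or still open, it means among the compounds named here.

Measured so far:
- compound 2, `COc1ccc(C(=O)c2sc(Nc3ccccc3)c(C(=O)O)c2C)cc1`: 36.5%
- compound 3, `Cc1ccc(C(=O)c2sc(Nc3ccccc3)c(C(=O)O)c2C)cc1`: 1.25%
- compound 1, `COC(=O)c1c(Nc2ccc(F)cc2)sc(C(=O)c2ccc(C)cc2)c1C`: "not active" (no number reported)

In a functional assay, with a stated time of 150 min, tested at 15 ug/mL (a lower number here means a weaker effect, a higher number a stronger effect of the compound at the concentration tested), compound 3 gives the lower of the two numbers reported; the change of a number 35.3 percentage points lower from compound 2 to compound 3 (beyond the scatter) separates it from compound 2, and compound 1 is reported without a number. Compound 4, `Cc1ccc(C(=O)c2sc(Nc3ccc(F)cc3)c(C(=O)O)c2C)cc1`, differs from compound 3 by fluoro in place of hydrogen on an aromatic carbon. Going by the values given here, no measured step covers this exact change: the only measured step concerns methyl in place of methoxy on another ring. Compound 1, which carries the (4-fluorophenyl)amino group but also a methyl ester instead of the acid, was found "not active" (no number reported), though it differs from compound 4 in two places. With compound 3 already near the bottom of the scale, a step of a number 2.8 percentage points higher from compound 3 to compound 4 (within the scatter) is expected, not beyond the scatter. Compound 4 is therefore estimated at 4%, with a range from 0% to 20%.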

Compound 4, a percentage reported as activity, at one concentration (the size of the read-out at that concentration, not a potency): "not active" (no number reported)
The entry for compound 4 holds no number; no gap can be computed for the estimate.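

Compound 4 is reported as "not active" (no number reported) and so gives no readable step from compound 3. As far as these compounds go, what swapping phenyl for 4-fluorophenyl does to the read-out stays open, and no supporting evidence bears on this result.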